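The source may report more compounds than this note shows. Statements on the series, on what has been measured and on what is new or still open speak of the compounds shown alone.

Measured in a functional assay on a cell-free system (Platelet, plasma, Homo sapiens) for inhibition; on this read-out lower numbers stand for stronger inhibition and higher numbers for weaker inhibition:
Compound 1 `O=C(Nc1cccc(OCc2ccccc2)c1)C1CCCNC1`: 128000 nM
Compound 2 `O=C(Nc1cccc(OCc2ccc(-c3ccccc3)cc2)c1)C1CCCNC1`: 153000 nM

Compound 2 at 153000 nM stands within the scatter of compound 1, and both are weak inhibitors on these numbers. Compound 3 `N=C(N)N1CCCC(C(=O)Nc2cccc(OCc3ccc(-c4ccccc4)cc3)c2)C1` differs from compound 2 by a group of 3 heavy atoms (1 carbon, 2 nitrogen; no ring) in place of a hydrogen atom, on an amine nitrogen in a ring on an amine nitrogen in a ring, two ring bonds from the ring atom that bears a large group. Among the compounds with values here, the only measured step, a 1.2-fold higher number from compound 1 to compound 2 (0.08 log units; within the scatter), is phenyl in place of hydrogen on an aromatic carbon. It stays within the scatter and lies elsewhere in the molecule, so it gives no direct measure for this change. Within the data shown here, no measured compound varies that nitrogen. In this assay a move to stronger inhibition is nevertheless expected, with an estimated size that is poorly bounded (a 10-fold lower number from compound 2 to compound 3 (1.01 log units; beyond the scatter)). For compound 3 the estimated value is 15000 nM (expected range 1500 nM to 120000 nM).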

Compound 3, half-maximal inhibitory concentration: 1000000 nM
The estimate for compound 3 lay 67-fold (1.82 log units) below the measured number, and the stated range ends below it.
By their numbers in this assay, from the lowest: compounds 1 and 2 (each within the scatter of the next); then compound 3.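

In this assay, within the data shown here, the amine nitrogen in the ring is the first position where a change moves the number beyond the scatter. A group of 3 heavy atoms (1 carbon, 2 nitrogen; no ring) in place of the hydrogen atom gives a 6.5-fold higher number from compound 2 to compound 3 (0.82 log units; beyond the scatter) and so weakens inhibition, whereas the earlier phenyl change remained within the scatter. This single pair therefore shows that the nitrogen is sensitive to substitution and that this group is not tolerated as well as hydrogen, but nothing available explains the loss.

Going by these compounds, whether a smaller group on that nitrogen, such as methyl or acetyl, also weakens inhibition remains open. Also open, on these data alone, is whether the same change has a similar effect on the core of compound 1, which lacks the added phenyl.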